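Methylsulfanyl in place of methylamino on a weak modulator

A few compounds are considered here, and "the series" means these few. Any claim that something is new, unique, unknown or untested is made for them only; others in the source may bear on it.

Measured so far:
compound 1 `CNc1ncc(C#Cc2ccc(C)cc2)cn1` gives 704000 nM
compound 2 `CCNc1ncc(C#Cc2ccccc2)cn1` gives "not active" (no number reported)
compound 3 `COc1ncc(C#Cc2cccc(C)c2)cn1` gives "not active" (no number reported)

For the measured compounds named here, in an assay on HEK293 cells for positive allosteric modulation of metabotropic glutamate receptor 5 (Rattus norvegicus) (on this read-out lower numbers stand for an effect already at smaller amounts and higher numbers for an effect only at larger amounts of compound), compound 1 is the only compound of the three with a number at all, and that number is very high, so an effect appears only at large amounts of compound. Compound 2 and compound 3 each carry a different group on the same aromatic carbon of the shared core and come back without any number in this assay. No pair among these three differs in a single place, so no step between measured compounds is available to guide the next one.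

Compound 4 `CSc1ncc(C#Cc2ccc(C)cc2)cn1` is the untested partner of compound 1. The change is methylsulfanyl in place of methylamino on an aromatic carbon. The methylamino group that leaves carries a hydrogen-bond donor; the methylsulfanyl group that enters carries none, and the place between two ring nitrogen atoms is the same one at which compounds 2 and 3 lost all measurable activity.

Because compound 1 gives 704000 nM and sits so near the top of the measurable range, the step from compound 1 to compound 4 is expected to be small, within the scatter or slightly toward larger amounts, a 1.3-fold higher number from compound 1 to compound 4 (0.11 log units; within the scatter). Compound 4 is therefore estimated to give 900000 nM, with a plausible range from 300000 nM to 3000000 nM, and a real chance that no number is reported at all.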

Compound 4, half-maximal effective concentration: "not active" (no number reported)
For compound 4 the study gives words and no number, so the estimate cannot be set against anything.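

For the compounds shown here, compound 4, like compound 1 a member of this series, comes back from this assay without a number, so no step from compound 1 to compound 4 can be read. The compounds shown leave open whether any group other than methylamino on this aromatic carbon gives a number at all. No evidence is available that bears on this result.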